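The compounds below may be only part of what the source reports. "The series", "measured", "known", "first", "only" and "open" are said of these compounds alone.

Of the compounds shown here, three have been tested in a toxicity assay on HepG2 cells (Homo sapiens) for inhibition, read by resazurin assay, with a stated time of 24 h; a higher number here means that more compound is tolerated, a lower number that less compound is tolerated: compound 1 `Cn1c([N+](=O)[O-])cnc1C(=O)N1CCCC1`, compound 2 `O=C(NC1CC1)c1ncc([N+](=O)[O-])[nH]1` and compound 3 `CNC(=O)c1nc([N+](=O)[O-])cn1Cc1ccc(OC(F)(F)F)cc1`. Compound 1 gives > 100000 nM, which is a limit of the assay and not a number. Compound 2 gives > 100000 nM, again a limit. Compound 3, the starting point of this account, gives > 100000 nM, also a limit. Compound 3 therefore has no exact number of its own, and its place is the limit of > 100000 nM in this assay, at which 3 of the 3 values shown sit.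

The next compound is compound 4 `NNC(=O)c1nc([N+](=O)[O-])cn1Cc1ccc(OC(F)(F)F)cc1`. It has amino in place of methyl on an amide-type nitrogen, and the counted difference from compound 3 is amino in place of methyl on an amide-type nitrogen. Among the measured compounds shown here, no two measured compounds differ in only one place, so no measured step guides this change. The expectation rests on compound 3, whose > 100000 nM is a limit. No step beyond the usual scatter is expected in this assay, although the limit leaves the true size of any change open, and a move in either direction cannot be ruled out. The expected change is a number no higher from compound 3 to compound 4 (the limit leaves the size open). Compound 4 is estimated at 100000 nM, with an expected range of 40000 nM to 200000 nM.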

Compound 4, half-maximal cytotoxic concentration: > 100000 nM
Compound 4 was reported as a limit; the forecaster's own chance of this, stated with the estimate: 65%; the middle value sits exactly at the limit.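

In this assay compound 4 gives > 100000 nM, which is a limit and not a number. Compound 3 also stands at a limit, so no step can be read between compound 3 and compound 4: the limit of > 100000 nM in this assay, at which 4 of the 4 values shown sit. The compounds shown leave open at what concentration, if any, each becomes toxic to these cells, and whether amino in place of methyl on an amide-type nitrogen changes that.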